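Adding a methyl to the pyrazole of compound 3

The source may hold more compounds than are shown below. What is called first, only, known or untested is meant among the compounds shown, and "the series" means these compounds.

Compound 3, `CC(=O)Nc1ccc(Cn2nc(Nc3cc[nH]n3)c3ccccc3c2=O)cc1`, was tested in a functional assay on MCF7 cells (Homo sapiens) for cytotoxicity; on this read-out higher numbers stand for weaker inhibition and lower numbers for stronger inhibition. In this assay compound 3 gives only a limit, > 30000 nM, and no number. Compound 1, `COc1ccc(Cn2nc(Nc3cc(C)[nH]n3)c3ccccc3c2=O)cc1`, carries on its pyrazole the methyl that compound 3 lacks; in this assay compound 1 likewise returns only the limit > 30000 nM. Compound 2, `Cc1cc(Nc2nn(Cc3ccc(S(C)(=O)=O)cc3)c(=O)c3ccccc23)n[nH]1`, gives 4500 nM in this assay. Among the compounds with values here, the one step that can be read is an at least 6.6-fold lower number from compound 1 to compound 2 (0.82 log units; beyond the scatter), and it concerns the group on the benzyl ring, not the pyrazole. Compound 4, `CC(=O)Nc1ccc(Cn2nc(Nc3cc(C)[nH]n3)c3ccccc3c2=O)cc1`, differs from compound 3 by methyl in place of hydrogen on an aromatic carbon. Within the data shown here, no measured step changes this position alone, so the step from compound 1 to compound 2 does not bear on it directly. What the values do show is that the two compounds sitting at the limit of > 30000 nM in this assay, at which 2 of the 3 values shown sit, differ in their benzyl substituent yet agree in showing no measurable inhibition, whether or not the pyrazole carries the methyl. Compound 4 is therefore expected to remain near the limit, with a number no higher from compound 3 to compound 4 (the limit leaves the size open) amounting to no step beyond the scatter. The estimate for compound 4 in this assay is 30000 nM, within 10000 nM to 100000 nM, and the assay is expected most likely to report only a limit again.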

Compound 4, half-maximal inhibitory concentration: > 30000 nM
Compound 4 gave a limit, no number; the forecaster's own chance of this, stated with the estimate: 70%; the middle value sits exactly at the limit.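

With the acetamido group on the benzyl ring, swapping 1H-pyrazol-3-yl for 5-methyl-1H-pyrazol-3-yl does not bring the compound off the limit, and the value of compound 4 is a limit and not a number: the limit of > 30000 nM in this assay, at which 3 of the 4 values shown sit. With the methyl present in both compounds, acetamido in place of methylsulfonyl gives an at least 6.6-fold higher number from compound 2 to compound 4 (0.82 log units; beyond the scatter), so among the compounds carrying this methyl, only compound 2 returns a number in this assay. The steps from compound 3 to compound 4 and from compound 1 to compound 4 cannot be read, as both ends of each are limits.

The compounds shown therefore leave open whether the methyl on the pyrazole changes the read-out at all, since the only number among them belongs to a methylsulfonyl compound that has no partner lacking the methyl. Also open, from the compounds shown here alone, is how a carboxylic acid, an amine or a longer chain in place of the methylsulfonyl on the benzyl ring would read in this assay.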